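The compounds below may be only part of what the source reports. "The series", "measured", "known", "first", "only" and "open" are said of these compounds alone.

Compound 1 `COc1ccc(Sc2cn(-c3ccc4c(c3)B(O)OC4)c3ccccc23)cc1` gives in an ADME assay on L929 cells (Mus musculus) for cytotoxicity, read by resazurin assay, with a stated time of 72 h (a lower number here means a stronger inhibitor, a higher number a weaker inhibitor), the limit > 10 ug/mL.
Compound 2 `O=C(NC1CCCCC1)c1cccn1-c1ccc2c(c1)B(O)OC2` gives in this assay the limit > 10 ug/mL.
Compound 3 `Cc1ccc(C(=O)c2ccn(-c3ccc4c(c3)B(O)OC4)c2)cc1` gives in this assay the limit > 10 ug/mL.

Compound 3 therefore stands only at a limit of this assay, not at a measured number; it shares the limit of > 10 ug/mL in this assay, at which 3 of the 3 values shown sit, with the two other compounds. Compound 4 `NCc1ccc(C(=O)c2ccn(-c3ccc4c(c3)B(O)OC4)c2)cc1` differs from compound 3 in one place: amino in place of hydrogen on a saturated chain carbon bound to an aromatic carbon. Among the measured compounds shown here, no step between measured compounds is available, so the size of this change in this assay cannot be read from the other compounds. The step from compound 3 to compound 4 is expected to be a step that the limit leaves unreadable from compound 3 to compound 4, none beyond the usual scatter. Compound 4 is estimated to give in this assay 15 ug/mL, within a range from 5 ug/mL to 50 ug/mL.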

Compound 4, half-maximal inhibitory concentration: > 10 ug/mL
Compound 4 was reported as a limit (the forecaster's own chance of this, stated with the estimate: 75%); the middle value lies beyond the limit too.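

In this assay, among the compounds shown here, compound 3 and compound 4 both stand only at a limit, so no step between them can be read: the limit of > 10 ug/mL in this assay, at which 4 of the 4 values shown sit. The compounds shown leave open what actual value any of them would give in this assay and whether amino in place of hydrogen changes it.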